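Removing the bromo from compound 2: what to expect

The source may hold more compounds than are shown below. What is called first, only, known or untested is meant among the compounds shown, and "the series" means these compounds.

Measured so far:
Compound 1, `CS(=O)(=O)c1cc(C(=O)N=C(N)N)c(F)cc1F`: 630 nM
Compound 2, `Cc1cc(Br)c(C(=O)N=C(N)N)cc1S(C)(=O)=O`: 70 nM

In a functional assay for inhibition of sodium/hydrogen exchanger (Oryctolagus cuniculus) (on this read-out lower numbers stand for stronger inhibition and higher numbers for weaker inhibition), compound 2 holds the lowest of the two numbers shown, and compound 1 gives 630 nM, a gap beyond the scatter. Compound 3, `Cc1ccc(C(=O)N=C(N)N)cc1S(C)(=O)=O`, is not yet measured. It differs from compound 2 by hydrogen in place of bromo on an aromatic carbon. For the measured compounds named here, no step between measured compounds shows the effect of this change alone, so the expectation rests on compound 2 alone. A weakening step is expected, a 4.3-fold higher number from compound 2 to compound 3 (0.63 log units; beyond the scatter), beyond the scatter. For compound 3 the estimated value is 300 nM, with a range from 100 nM to 1000 nM.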

Compound 3, half-maximal inhibitory concentration: 210 nM
For compound 3 the middle estimate is 1.4-fold (0.15 log units) above the measured one; the range from low to high includes it.
By their numbers in this assay, from the lowest: compound 2; then compound 3; then compound 1.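

For the compounds shown here, on this aromatic carbon, para to a methylsulfonyl group, hydrogen in place of bromo gives a 3.0-fold higher number from compound 2 to compound 3 (0.48 log units; beyond the scatter) in this assay and so shows the effect of this change alone for the first time, a modest weakening. The bromo is thus not required for inhibition on this core, since compound 3 at 210 nM still gives a measurable number. Nothing at hand explains the size of this step.

On these data alone, whether chloro, methoxy or an amine on this carbon would give a lower or higher number stays open. So does whether the step would keep its size with an ethyl group in place of the methyl group.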